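Nitro to Amino on a Fused Ring: Cytotoxicity

A few compounds are considered here, and "the series" means these few. Any claim that something is new, unique, unknown or untested is made for them only; others in the source may bear on it.

Compound 1 `CCn1cc(-c2nc3ccc([N+](=O)[O-])cc3[nH]2)c(=O)c2cc(F)c(N3CCNCC3)nc21`: 22400 nM
Compound 2 `CCn1cc(-c2nc3ccc([N+](=O)[O-])cc3[nH]2)c(=O)c2cc(F)c(N3CCN(C)CC3)cc21`: 2500 nM
Compound 3 `CCn1cc(-c2nc3ccc(N)cc3[nH]2)c(=O)c2cc(F)c(N3CCN(C)CC3)cc21`: > 50000 nM, a limit of the assay

All three were tested in a functional assay on KB cells (Homo sapiens) for cytotoxicity, read by MTT assay, with a stated time of 48 h; on this read-out lower numbers stand for stronger inhibition and higher numbers for weaker inhibition. Compound 3 reaches only a limit, (the limit of > 50000 nM in this assay, at which 1 of the 3 values shown sits). Compounds 1 and 2 share a related core, but the difference between the two cores is not broken down here; compound 2 gives a lower number than compound 1. From compound 2 to compound 3 the change is amino in place of nitro on an aromatic carbon, and it gave an at least 20-fold higher number from compound 2 to compound 3 (1.30 log units; beyond the scatter).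

Compound 4 `CCn1cc(-c2nc3ccc(N)cc3[nH]2)c(=O)c2cc(F)c(N3CCNCC3)nc21` is not yet measured. It differs from compound 1 by amino in place of nitro on an aromatic carbon, the same change as from compound 2 to compound 3. Since compound 1 already gives 22400 nM, a step like an at least 20-fold higher number from compound 2 to compound 3 (1.30 log units; beyond the scatter) would carry compound 4 past the limit; the expected step is a 13-fold higher number from compound 1 to compound 4 (1.13 log units; beyond the scatter). Compound 4 is therefore estimated at 300000 nM in this assay, most likely reported only as a limit.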

Compound 4, half-maximal inhibitory concentration: 30100 nM
Beside the measured number, compound 4's estimate is 10-fold (1.00 log units) above it; the whole stated range lies above it.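

In this assay, amino in place of nitro gave a 1.3-fold higher number from compound 1 to compound 4 (0.13 log units; within the scatter), so the large step seen on the other core did not carry over to the core of compound 1: the same change on two cores in this assay, an at least 20-fold higher number (1.30 log units; beyond the scatter) from compound 2 to compound 3 and a 1.3-fold higher number (0.13 log units; within the scatter) from compound 1 to compound 4, at least 14-fold (1.17 log units) apart, beyond the scatter of two such steps. This shows that, across these two pairs, the effect of the change depends on the core, but it does not show which of the differences between the two cores matters. Compound 3 gives > 50000 nM, which is a limit of the assay.

Still open, on these data alone, is how another group on the same aromatic carbon, such as a methoxy group or a carboxylic acid, would behave on each core. Among the compounds shown here, with only two pairs, it also remains open how the change would behave on any further core.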